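Sulfonamide heteroaryl swap on a coumarin enaminone series

The compounds below may be only part of what the source reports. "The series", "measured", "known", "first", "only" and "open" are said of these compounds alone.

Two compounds of the series carry a number in a functional assay on T47D cells (Homo sapiens) for cytotoxicity, read by sulforhodamine B assay, with a stated time of 48 h; on this read-out higher numbers stand for weaker inhibition and lower numbers for stronger inhibition. Compound 1 `Cc1nnc(NS(=O)(=O)c2ccc(N/C=C\C(=O)c3cc4ccccc4oc3=O)cc2)s1` gives 94000 nM and compound 2 `Cc1cc(C)nc(NS(=O)(=O)c2ccc(N/C=C\C(=O)c3cc4ccccc4oc3=O)cc2)n1` gives 62200 nM. The single measured step, a 1.5-fold lower number from compound 1 to compound 2 (0.18 log units; within the scatter), exchanges one heteroaryl group on the sulfonamide nitrogen for another and stays within the scatter, so on the numbers shown compound 2 has the lowest value but is not separated from compound 1.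

Compound 3 `COc1cnc(NS(=O)(=O)c2ccc(N/C=C\C(=O)c3cc4ccccc4oc3=O)cc2)nc1` is not yet measured. It differs from compound 2 by 5-methoxypyrimidin-2-yl in place of 4,6-dimethylpyrimidin-2-yl on a sulfonamide nitrogen. Within the data shown here, the only step that bears on it is the heteroaryl exchange from compound 1 to compound 2, which moved the number within the scatter; the methoxy-for-dimethyl exchange on the same pyrimidine is of similar scope. Because a 1.5-fold lower number from compound 1 to compound 2 (0.18 log units; within the scatter) was small, no step beyond the scatter is expected for compound 3 in this assay. The estimate for compound 3 is therefore 70000 nM, with a range of 30000 nM to 160000 nM, which corresponds to an expected step of a 1.1-fold higher number from compound 2 to compound 3 (0.05 log units; within the scatter).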

Compound 3, half-maximal inhibitory concentration: 8800 nM
Estimate against measurement, compound 3: 8.0-fold (0.90 log units) above, and the stated range ends above it.
By their numbers in this assay, from the lowest: compound 3; then compounds 2 and 1 (each within the scatter of the next).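

In this assay, the group on the sulfonamide nitrogen can now be seen to move the number beyond the scatter: 5-methoxypyrimidin-2-yl in place of 4,6-dimethylpyrimidin-2-yl gives a 7.1-fold lower number from compound 2 to compound 3 (0.85 log units; beyond the scatter), and the same group in place of 5-methyl-1,3,4-thiadiazol-2-yl gives an 11-fold lower number from compound 1 to compound 3 (1.03 log units; beyond the scatter). Both groups in the first of these steps are pyrimidines with the same count of heavy atoms, so among the compounds shown, the pyrimidine ring alone does not set the number, and the substituents on it must be taken into account. No measurement is available that explains the separation of compound 3 from compound 2 and compound 1.

The compounds shown leave open whether the lower number goes with the methoxy group itself or with the loss of the two methyl groups, a question that a pyrimidin-2-yl carrying no substituent would help to settle. They also leave open how much change the methoxy group tolerates, which an ethoxy group or an amine in its place would test.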